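The compounds below may be only part of what the source reports. "The series", "measured", "known", "first", "only" and "open" are said of these compounds alone.

The measured compounds:

compound 1, `O=C(/C=C/c1ccc(F)cc1)Nc1nnc(-c2ccccc2)s1`, 1.45 ug/mL
compound 2, `Cc1ccc(-c2nnc(NC(=O)/C=C/c3ccc(F)cc3)s2)cc1`, 1.27 ug/mL
compound 3, `O=C(/C=C/c1ccccc1)Nc1nnc(-c2ccc(Br)cc2)s1`, 1.5 ug/mL

All three were tested in a functional assay on MCF7 cells (Homo sapiens) for antiproliferative activity, read by MTT assay, with a stated time of 48 h; a lower number here means a stronger inhibitor, a higher number a weaker inhibitor. Compound 1 gives 1.45 ug/mL in this assay, and compound 2 gives 1.27 ug/mL. The only difference between them is methyl in place of hydrogen on an aromatic carbon, and this change made a step of a 1.1-fold lower number from compound 1 to compound 2 (0.06 log units; within the scatter), so the two values cannot be told apart. Compound 3, measured at 1.5 ug/mL, sits alongside both of them; its value and that of compound 1 are within the scatter of each other, as are its value and that of compound 2. How the core of compound 3 differs from the core of compound 1 is not broken down here.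

Compound 4, `Cc1ccc(/C=C/C(=O)Nc2nnc(-c3ccc(Br)cc3)s2)cc1`, has not yet been measured. It differs from compound 3 by methyl in place of hydrogen on an aromatic carbon. The place of this change is described in the same words as for the pair of compound 1 and compound 2, so it is the same change, carried out on the core of compound 3 rather than that of compound 1. Because the earlier step of a 1.1-fold lower number from compound 1 to compound 2 (0.06 log units; within the scatter) stayed within the scatter, the step expected here is likewise small, an estimated 1.1-fold lower number from compound 3 to compound 4 (0.03 log units; within the scatter). On that basis compound 4 is expected to give about 1.4 ug/mL, with a likely range from 0.9 ug/mL to 2.2 ug/mL.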

Compound 4, half-maximal inhibitory concentration: 1.32 ug/mL
The estimate for compound 4 lay 1.1-fold (0.03 log units) above the measured number; the range from low to high includes it.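

In this assay, placing methyl in place of hydrogen on an aromatic carbon, which here turns phenyl into 4-methylphenyl, gave a 1.1-fold lower number from compound 3 to compound 4 (0.06 log units; within the scatter), so the two compounds cannot be told apart. Set beside the earlier case, the step shows no difference between the two cores: the same change on two cores in this assay, a 1.1-fold lower number (0.06 log units; within the scatter) from compound 1 to compound 2 and a 1.1-fold lower number (0.06 log units; within the scatter) from compound 3 to compound 4, 1.0-fold (0.00 log units) apart, within the scatter of two such steps This shows that, on these two cores, the change left the number within the scatter each time, but it does not show that methyl has a real effect of a shared size, since two steps this small agree only in being indistinguishable from no change, and two cores cannot speak for the whole series.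

Going by these compounds, what happens at the same place with an amine, a carboxylic acid or a longer chain remains open, and so does whether any such group would give a step beyond the scatter. On these data alone, it is also open whether methyl would give an equally small step on a core carrying a nitrile or a methoxy group where compound 3 carries its bromine.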